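The compounds below may be only part of what the source reports. "The series", "measured", "known", "first", "only" and "open" are said of these compounds alone.

Of the compounds shown here, two built on the same core have been tested so far. Compound 2 `N#C/C(=C\N1CCN(C(=O)c2ccco2)C1=S)C(N)=O` is measured in a functional assay on SK-MEL-28 cells (Homo sapiens) for inhibition, read by sulforhodamine B assay, with a stated time of 48 h (a higher number here means a weaker inhibitor of growth, a lower number a stronger inhibitor of growth), and gives 15800 nM. Compound 1 `N#C/C(=C\N1CCN(C(=O)c2ccco2)C1=S)C(=O)Nc1ccc(Cl)cc1` carries a 4-chlorophenyl group on the amide-type nitrogen where compound 2 carries a hydrogen. In this assay compound 1 gives a value of 18700 nM. The step of a 1.2-fold lower number from compound 1 to compound 2 (0.07 log units; within the scatter) lies within the usual scatter, so the two values cannot be ranked; compound 2 simply carries the lower of the two numbers.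

Compound 3 `N#C/C(=C\N1CCN(C(=O)c2ccco2)C1=S)C(=O)c1ccccc1` has not yet been measured. It differs from compound 2 in that (phenyl in place of amino on a carbonyl carbon). Going by the values given here, the one measured step, a 1.2-fold lower number from compound 1 to compound 2 (0.07 log units; within the scatter), changed what sits on the amide-type nitrogen rather than what sits on the carbonyl carbon, so it bears on the new change only as a hint that large groups near the carbonyl have so far moved the number little. On that basis the expected step in this assay is small, and no change beyond the scatter is expected: the estimated step is a 1.3-fold lower number from compound 2 to compound 3 (0.12 log units; within the scatter). Compound 3 is therefore expected to give about 12000 nM, with a range from 4000 nM to 40000 nM.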

Compound 3, concentration for 50% growth inhibition: 28000 nM
The estimate for compound 3 lay 2.3-fold (0.37 log units) below the measured number; low and high end bracket the measured number.
By their numbers in this assay, from the lowest: compounds 2, 1 and 3 (each within the scatter of the next).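

In this assay, phenyl in place of amino on the carbonyl carbon, which turns carbamoyl into benzoyl, gives a 1.8-fold higher number from compound 2 to compound 3 (0.25 log units; within the scatter). Phenyl in place of (4-chlorophenyl)amino at the same carbon gives a 1.5-fold higher number from compound 1 to compound 3 (0.18 log units; within the scatter). Both steps lie within the scatter, so compounds 1, 2 and 3 cannot be told apart, and this now covers a compound with no nitrogen on that carbonyl carbon: the amino group and its hydrogen-bond donor are gone in compound 3, yet its number stays within the scatter of the other two, a point the earlier pair could not show. Nothing available here explains why these three values lie so close together.

Going by these compounds, all three compounds sit in the same high range of numbers, so it remains open whether any group on this carbonyl carbon can move the number beyond the scatter, for example a hydroxyl group giving a carboxylic acid, a methoxy group giving a methyl ester, or a longer chain. On these data alone, it is also open whether substituents on the phenyl of compound 3, such as the chlorine carried by compound 1, would matter once the nitrogen is absent.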